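Compound 1 Gains a Trifluoromethyl Group

A few compounds are considered here, and "the series" means these few. Any claim that something is new, unique, unknown or untested is made for them only; others in the source may bear on it.

Compound 1 `Cc1ccc2cccc(NS(=O)(=O)c3ccccc3[N+](=O)[O-])c2n1`: 8000 nM
Compound 2 `O=[N+]([O-])c1cc(C(F)(F)F)ccc1S(=O)(=O)Nc1cccc2cccnc12`: 20000 nM

In an assay on OCI-Ly3 cells for activation of NF-kappa-B inhibitor alpha (Homo sapiens), read by a luciferase reporter (on this read-out higher numbers stand for an effect only at larger amounts of compound and lower numbers for an effect already at smaller amounts), compound 1 gives 8000 nM, the lowest of the two numbers. Compound 2 gives 20000 nM, a gap beyond the scatter. Among the measured compounds shown here, no single step between the two measured compounds is described. Compound 3 `Cc1ccc2cccc(NS(=O)(=O)c3ccc(C(F)(F)F)cc3[N+](=O)[O-])c2n1` differs from compound 1 by trifluoromethyl in place of hydrogen on an aromatic carbon. Compound 2 carries the same trifluoromethyl group but lacks the methyl of compound 1, so the two measured values do not separate the two changes. The step of a 1.5-fold higher number from compound 1 to compound 3 (0.18 log units; within the scatter) is expected to be small, toward a higher number, close to the scatter. Compound 3 is estimated at 12000 nM, within 5000 nM to 30000 nM.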

Compound 3, half-maximal effective concentration: 3600 nM
Estimate against measurement, compound 3: 3.3-fold (0.52 log units) above, and the stated range ends above it.
By their numbers in this assay, from the lowest: compound 3; then compound 1; then compound 2.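

With the two changes now separated, trifluoromethyl in place of hydrogen on this aromatic carbon, meta to a nitro group and para to a large group, gives a 2.2-fold lower number from compound 1 to compound 3 (0.35 log units; beyond the scatter) in this assay. The methyl change, on the same trifluoromethyl-bearing scaffold, gives a 5.6-fold lower number from compound 2 to compound 3 (0.74 log units; beyond the scatter), so each change on its own moves toward a lower number. No measurement here accounts for either step. Going by these compounds, whether an amine, a carboxylic acid or a chlorine atom at this carbon would move the number the same way remains open.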